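Methyl on the central ring of a biaryl anilide pair

The source may report more compounds than this note shows. Statements on the series, on what has been measured and on what is new or still open speak of the compounds shown alone.

Measured so far:
compound 1, `Cc1cccnc1-c1ccc(C(=O)Nc2ccc(C(C)C)cc2)cc1`, 73 nM
compound 2, `Cc1cccnc1-c1ccc(C(=O)Nc2ccc(C(F)(F)F)cc2)cc1`, 65 nM

Compound 2 holds the lowest of the two numbers in a functional assay for antagonist activity at transient receptor potential cation channel subfamily V member 1 (Homo sapiens), read by FLIPR (on this read-out lower numbers stand for stronger inhibition and higher numbers for weaker inhibition), but its neighbour compound 1 sits within the scatter: the step of a 1.1-fold lower number from compound 1 to compound 2 (0.05 log units; within the scatter) changes nothing that can be read as a difference. Compound 3, `Cc1cc(-c2ncccc2C)ccc1C(=O)Nc1ccc(C(F)(F)F)cc1`, keeps the trifluoromethyl anilide of compound 2 and adds methyl in place of hydrogen on an aromatic carbon on an aromatic carbon of a six-membered aromatic ring of carbon only, ortho to a large group. Within the data shown here, no measured step touches this ring; the only step available, from compound 1 to compound 2, alters the other end of the molecule and lies within the scatter, so it offers no direction for this change. The expectation for compound 3 is therefore a step of a 1.3-fold higher number from compound 2 to compound 3 (0.12 log units; within the scatter), with no movement beyond the scatter foreseen. Compound 3 is estimated at 85 nM, between 25 nM and 300 nM.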

Compound 3, half-maximal inhibitory concentration: > 4000 nM
Compound 3: a limit, no number; the forecaster's own chance of this, stated with the estimate: 5%; middle value at least 47-fold (1.67 log units) away from the limit.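

In this assay, methyl in place of hydrogen on the six-membered aromatic ring of carbon only, ortho to a large group, gives an at least 61-fold higher number from compound 2 to compound 3 (1.78 log units; beyond the scatter), so this position does not tolerate even this single added heavy atom in the trifluoromethyl anilide. Compound 3 carries a limit of the assay, not a number: the limit of > 4000 nM in this assay, at which 1 of the 3 values shown sits. Among these compounds, the only earlier step, a 1.1-fold lower number from compound 1 to compound 2 (0.05 log units; within the scatter), lay at the anilide end and gave no warning of how sensitive this ring would be, so tolerance there says nothing about tolerance here.

As far as these compounds go, whether the loss belongs to methyl itself or to any group on this carbon stays open; fluorine, chlorine or a methoxy group there would separate the two. Also open, from the compounds shown here alone, is whether the isopropyl anilide of compound 1 responds in the same way to this methyl.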